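A few compounds are considered here, and "the series" means these few. Any claim that something is new, unique, unknown or untested is made for them only; others in the source may bear on it.

Working notes on the sulfonamide series, read in a functional assay on CHO cells for positive allosteric modulation of muscarinic acetylcholine receptor M5 (Homo sapiens), read by calcium flux; on this read-out higher numbers stand for larger maximal responses and lower numbers for smaller maximal responses.

Compound 1 `CCN(Cc1ccccc1)C(=O)C1CCN(S(=O)(=O)c2ccc(OC)cc2)CC1` gives 84% in this assay. Within the data shown here, compound 2 `CCN(Cc1ccccc1)C(=O)C1CCN(S(=O)(=O)c2ccc(OC)c(OC)c2)CC1` gives 57%, and the step of a number 27 percentage points lower from compound 1 to compound 2 (beyond the scatter) is the only measured step in the set. Compound 3 `CCN(Cc1ccccc1)C(=O)C1CCN(S(=O)(=O)c2c(C)noc2C)CC1` has no result in this assay; its entry stands as "not determined" (no result reported). On the numbers available, compound 2 is the lowest of the two, with compound 1 the nearest and higher by a margin beyond the scatter.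

Compound 4 `CCN(Cc1ccccc1)C(=O)C1CCN(S(=O)(=O)c2ccc3cn[nH]c3c2)CC1` differs from compound 2 in one place: 1H-indazol-6-yl in place of 3,4-dimethoxyphenyl on a sulfonyl sulfur. Among the measured compounds shown here, the one measured step, which shows that adding a methoxy on an aromatic carbon from compound 1 to compound 2 cost a modest amount, bears on this change only in part, since both methoxy groups leave and a 1H-indazol-6-yl enters in place of 3,4-dimethoxyphenyl. Given that a number 27 percentage points lower from compound 1 to compound 2 (beyond the scatter) was modest, the step from compound 2 to compound 4 is expected to be an upward one, a number 13 percentage points higher from compound 2 to compound 4 (beyond the scatter), bringing the response back toward the level of compound 1 but with wide uncertainty. Compound 4 is therefore estimated at 70% in this assay, within 45% to 95%.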

Compound 4, largest response reached (reported as percent of maximum), in percent of the reference or control that the assay uses: 86%
Compound 4: the middle estimate sits 16 percentage points below what was measured, within the range that was stated.
By their numbers in this assay, from the lowest: compound 2; then compounds 1 and 4 (each within the scatter of the next).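

On the sulfonyl sulfur, 1H-indazol-6-yl in place of 3,4-dimethoxyphenyl gives a number 29 percentage points higher from compound 2 to compound 4 (beyond the scatter) in this assay, so the lower response of compound 2 is not common to every group at this place. Set against the 4-methoxyphenyl group, the same change gives a number 2 percentage points higher from compound 1 to compound 4 (within the scatter), which shows that a methoxy group is not required here for a maximal response on the level of compound 1. Nothing available explains why the response shifts with these groups.

Compound 3 carries no number and so offers no comparison for its group. Still open, on these data alone, are how an unsubstituted phenyl or a pyridyl group would read on the sulfonyl sulfur, and whether the ring hydrogen of 1H-indazol-6-yl matters for the response.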